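The source may report more compounds than this note shows. Statements on the series, on what has been measured and on what is new or still open speak of the compounds shown alone.

Measured in a functional assay on K562 cells (Homo sapiens) for cytotoxicity, read by sulforhodamine B assay; on this read-out higher numbers stand for weaker inhibition of growth and lower numbers for stronger inhibition of growth:

- Compound 1 `CC1=CC[C@@H]([C@@](C)(O)CCCC(C)(C)NC(=S)N/N=C\c2ccc(C)cc2)CC1`: 7950 nM
- Compound 2 `CC1=CC[C@@H]([C@@](C)(O)CCCC(C)(C)NC(=S)N/N=C\c2ccccc2[N+](=O)[O-])CC1`: 7840 nM

On these numbers, compound 2 at 7840 nM cannot be told apart from compound 1 at 7950 nM, and these are the only two measured so far. The next compound to be tested is compound 3 `CC1=CC[C@@H]([C@@](C)(O)CCCC(C)(C)NC(=S)N/N=C\c2ccc(Cl)cc2)CC1`, which differs from compound 2 as follows: 4-chlorophenyl in place of 2-nitrophenyl on a carbon with a double bond to nitrogen. In short, 4-chlorophenyl stands in place of 2-nitrophenyl on a carbon with a double bond to nitrogen.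

Among the compounds with values here, only one measured step bears on this change. In a 1.0-fold lower number from compound 1 to compound 2 (0.01 log units; within the scatter), swapping 4-methylphenyl for 2-nitrophenyl at that same place left the number within the scatter. A single step is thin evidence, but it gives no reason to expect a real shift in this assay. The expected change is a 1.0-fold lower number from compound 2 to compound 3 (0.02 log units; within the scatter), which means no step beyond the scatter in either direction. For compound 3 the estimated value is 7500 nM, with an expected range of 4000 nM to 14000 nM.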

Compound 3, concentration for total growth inhibition: 730 nM
Beside the measured number, compound 3's estimate is 10-fold (1.01 log units) above it, and the stated range ends above it.
By their numbers in this assay, from the lowest: compound 3; then compounds 2 and 1 (each within the scatter of the next).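

In this assay, this place on the carbon with a double bond to nitrogen turns out to matter: 4-chlorophenyl in place of 2-nitrophenyl gives an 11-fold lower number from compound 2 to compound 3 (1.03 log units; beyond the scatter), although the earlier swap here stayed within the scatter. The cleanest comparison is an 11-fold lower number from compound 1 to compound 3 (1.04 log units; beyond the scatter), since only chloro in place of methyl on an aromatic carbon separates the pair, so a small edit to the ring can produce a large step. Nothing available here explains why chloro behaves so differently.

On these data alone, it remains open whether this lower number is particular to chloro or would also appear with 4-fluorophenyl or 4-bromophenyl. Also open, as far as these compounds go, is whether 2-chlorophenyl would match 4-chlorophenyl, which would show how much the place of the chloro on the ring matters.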